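A few compounds are considered here, and "the series" means these few. Any claim that something is new, unique, unknown or untested is made for them only; others in the source may bear on it.

In a functional assay on HeLa cells (Homo sapiens) for inhibition, read by MTT assay, with a stated time of 48 h (on this read-out higher numbers stand for weaker inhibition and lower numbers for stronger inhibition), compound 1 `CCOC(=O)C1=C(N/N=C(/C(=O)Br)c2ccc(Br)cc2)Nc2[nH]nc(C)c2C1c1ccc(N(C)C)cc1` gives 68500 nM and compound 2 `CCOC(=O)C1=C(N/C=N/c2ccc(C)cc2)Nc2[nH]nc(C)c2C1c1ccc(N(C)C)cc1` gives 43200 nM as its value, the two lying within the scatter of each other. Compound 3 `CCOC(=O)C1=C(N)Nc2[nH]nc(C)c2C1c1ccc(N(C)C)cc1` differs from compound 2 by a hydrogen atom in place of a group of 9 heavy atoms (8 carbon, 1 nitrogen; one six-membered aromatic ring of carbon only), on an amine nitrogen on an amine nitrogen, leaving a hydrogen atom there. Among the compounds with values here, the one measured step at such a nitrogen, a 1.6-fold lower number from compound 1 to compound 2 (0.20 log units; within the scatter) within the scatter, exchanged one large group for another. Within the data shown here, no measured compound carries hydrogen there. A step beyond the scatter is therefore not expected in this assay and no direction is favoured. The expected step is a 1.3-fold higher number from compound 2 to compound 3 (0.10 log units; within the scatter) in size. For compound 3 the estimated value is 55000 nM with an expected range from 22000 nM to 130000 nM in this read-out.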

Compound 3, half-maximal inhibitory concentration: 6220 nM
The estimate for compound 3 lay 8.8-fold (0.95 log units) above the measured number, and the stated range ends above it.
By their numbers in this assay, from the lowest: compound 3; then compounds 2 and 1 (each within the scatter of the next).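

In this assay the exchange for a hydrogen atom on this amine nitrogen gives a 6.9-fold lower number from compound 2 to compound 3 (0.84 log units; beyond the scatter) and an 11-fold lower number from compound 1 to compound 3 (1.04 log units; beyond the scatter) and is the only kind of change at this position shown to go beyond the scatter. Both large groups therefore give higher numbers than the unsubstituted nitrogen, although exchanging one for the other did not separate them. Still open, from the compounds shown here alone, is whether a small group on this nitrogen, such as methyl or acetyl, keeps the lower number or whether the hydrogen atom itself is required. No available evidence explains this step.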